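The source may report more compounds than this note shows. Statements on the series, on what has been measured and on what is new or still open speak of the compounds shown alone.

Going by the values given here, in a functional assay on MV4-11 cells (Homo sapiens) for inhibition, read by luminescence, with a stated time of 72 h, tested at 5 uM (on this read-out lower numbers stand for less inhibition of growth and higher numbers for more inhibition of growth at the one concentration tested), compound 2 (`COc1cc(O)c(C(=O)OCC(C)c2ccccc2)c(/C=C/CN2C(=O)C=CC2=O)c1`) gives 99% and stands highest of the two numbers so far, while compound 1 (`C=CS(=O)(=O)NC/C=C/c1cc(OC)cc(O)c1C(=O)OC(C)C`) gives 72.3% and lies lower by more than the scatter. Compound 3 (`COc1cc(O)c(C(=O)OC(C)C)c(/C=C/CN2C(=O)C=CC2=O)c1`) has isopropyl in place of 2-phenylpropyl on an oxygen next to a carbonyl group. Among the compounds with values here, no measured pair shows this change alone, but compound 1 also carries isopropyl and gives 72.3% so a moderate fall in this assay is expected. The expected a number 14 percentage points lower from compound 2 to compound 3 (beyond the scatter) would lie just beyond the scatter. For compound 3 the estimate is 85% with an expected range from 62% to 100% on this read-out.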

Compound 3, percent growth inhibition at one concentration: 99.8%
Estimate against measurement, compound 3: 14.8 percentage points below, within the range that was stated.
By their numbers in this assay, from the lowest: compound 1; then compounds 2 and 3 (each within the scatter of the next).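

In this assay, isopropyl in place of 2-phenylpropyl on an oxygen next to a carbonyl group gives a number 0.8 percentage points higher from compound 2 to compound 3 (within the scatter), so the ring of 2-phenylpropyl is not needed at this position for the growth inhibition seen at the one concentration tested. With isopropyl on both compounds, the group with the five-membered non-aromatic ring, replacing the group with no ring, gives a number 27.5 percentage points higher from compound 1 to compound 3 (beyond the scatter), so the gain goes with that change. Nothing here gives a reason for either step.

From the compounds shown here alone, whether a methyl group or a benzyl group on that oxygen would keep this level remains open. Any difference between compound 2 and compound 3 at lower concentrations also remains open.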